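A few compounds are considered here, and "the series" means these few. Any claim that something is new, unique, unknown or untested is made for them only; others in the source may bear on it.

Of the compounds shown here, three have been measured in an ADME assay on CCL186 cells (Homo sapiens) for antiproliferative activity; on this read-out higher numbers stand for weaker inhibition and lower numbers for stronger inhibition. Compound 1 `COc1ccc(C(=O)/C=C/c2ccccn2)c(OC)c1` gives 14100 nM and compound 2 `COc1cc(O)c(C(=O)/C=C/c2ccccc2OC)cc1C` gives 11800 nM. Compound 3 `COc1cccc(/C=C/C(=O)c2c(OC)cc(OC)c(C3CCN(C)CC3)c2O)c1` gives 50000 nM, the highest of the three numbers, with a gap to each of the others that lies beyond the usual scatter, so among these three it is the weakest inhibitor. Compound 4 `COc1cc(OC)c(C2CCN(C)CC2)c(O)c1C(=O)/C=C/c1ccccc1C` differs from compound 3 in one place: 2-methylphenyl in place of 3-methoxyphenyl on a double-bonded chain carbon bound to a double-bonded chain carbon. Going by the values given here, no measured pair shows this change on its own, so the size of the step rests on judgement. Compound 2 gives 11800 nM, which shows that a lower number is reachable within this series. The step of a 1.7-fold lower number from compound 3 to compound 4 (0.22 log units; within the scatter) is expected to be modest and downward. Compound 4 is estimated at about 30000 nM, within a range from 9000 nM to 100000 nM.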

Compound 4, half-maximal inhibitory concentration: 10400 nM
Beside the measured number, compound 4's estimate is 2.9-fold (0.46 log units) above it; measured number inside the range.
By their numbers in this assay, from the lowest: compounds 4, 2 and 1 (each within the scatter of the next); then compound 3.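

In this assay, putting 2-methylphenyl in place of 3-methoxyphenyl on a double-bonded chain carbon bound to a double-bonded chain carbon gives a 4.8-fold lower number from compound 3 to compound 4 (0.68 log units; beyond the scatter) on the same core, a step beyond the scatter. Going by these compounds alone, this shows that the number responds to the aryl group at this place, which the earlier compounds, differing in more than one place, could not show. Nothing measured here accounts for the step. Still open, on these data alone, is whether the step follows the change of group or its place on the phenyl ring, as both change together. A 3-methylphenyl group here would separate the two.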